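The source may hold more compounds than are shown below. What is called first, only, known or untested is meant among the compounds shown, and "the series" means these compounds.

Compounds measured:
- compound 1, `Cc1ccc(OCC(=O)N(Cc2cccs2)c2cnn(C)c2)cc1`, 63000 nM
- compound 2, `CCN(Cc1cccs1)C(=O)COc1ccc(CO)cc1`, 21900 nM

In an assay on HEK293 cells for agonist activity at transient receptor potential cation channel subfamily M member 8 (Homo sapiens), read by fluorescence and calcium flux, with a stated time of 15 min (on this read-out higher numbers stand for an effect only at larger amounts of compound and lower numbers for an effect already at smaller amounts), compound 1 gives 63000 nM, the higher of the two numbers; compound 2 gives 21900 nM, and the gap between them lies beyond the scatter of repeated measurements. Compound 3, `Cc1ccc(OCC(=O)N(Cc2cccs2)C(C)C)cc1`, has not yet been tested in this assay. It differs from compound 1 in one place: isopropyl in place of 1-methyl-1H-pyrazol-4-yl on an amide-type nitrogen. Among the measured compounds shown here, no measured pair shows this change, so its effect is open. Compound 2, carrying an ethyl on that nitrogen, gives the lower number, and a modest step downward from compound 1 is therefore expected. Compound 3 is estimated at 25000 nM, ranging from 6000 nM to 100000 nM, a step of a 2.5-fold lower number from compound 1 to compound 3 (0.40 log units; beyond the scatter).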

Compound 3, half-maximal effective concentration: 70 nM
For compound 3 the middle estimate is 360-fold (2.55 log units) above the measured one; the whole stated range lies above it.
By their numbers in this assay, from the lowest: compound 3; then compound 2; then compound 1.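

In this assay, the amide-type nitrogen proves to be a highly sensitive position: isopropyl in place of 1-methyl-1H-pyrazol-4-yl gives a 900-fold lower number from compound 1 to compound 3 (2.95 log units; beyond the scatter). The two earlier compounds differ in more than one place, so they could not show this position on its own. No available measurement explains the size of this step.

On these data alone, it remains open whether the step belongs to isopropyl itself or would also come with cyclopropyl or tert-butyl on that nitrogen. As far as these compounds go, it is equally open whether phenyl there would place a compound nearer compound 1 or compound 3.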